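The compounds below may be only part of what the source reports. "The series", "measured", "known", "first", "only" and "open" are said of these compounds alone.

Working notes on the series in an ADME assay on HEK293 cells (Homo sapiens) for cytotoxicity, read by resazurin assay, with a stated time of 24 h; a higher number here means that more compound is tolerated, a lower number that less compound is tolerated.

Three members have been run so far. Compound 1 `Oc1cc(CCc2ccccc2)cc(O)c1O` gives 106000 nM in this assay. Compound 2 `COc1cc(O)c(C(=O)O)c(CCc2ccc3ccccc3c2)c1` gives 65000 nM in this assay. Compound 3 `CCN(CC)C(=O)c1c(/C=C\c2ccc3ccccc3c2)cc(OC)cc1OC` returns only a limit and not a number in this assay: > 100000 nM. Within the data shown here, compound 3 therefore sits at the limit of > 100000 nM in this assay, at which 1 of the 3 values shown sits, while compound 1 and compound 2 both return numbers, and no step between any two of these measured compounds has been characterised, so nothing more is taken from the pair of compound 1 and compound 2 than what their two values show.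

The next member is compound 4 `CCN(CC)C(=O)c1c(/C=C/c2ccc3ccccc3c2)cc(OC)cc1OC`. Against compound 3 the change is the two compounds have the same atoms and bonds and differ only in configuration as drawn: 1 of 1 stereo elements differ; a double bond is drawn Z in compound 3 and E in compound 4. Among the measured compounds shown here, no measured step speaks to a change of this kind, so the expectation for compound 4 rests on compound 3 alone. The step from compound 3 to compound 4 is expected to be none beyond the usual scatter, that is a step that the limit leaves unreadable from compound 3 to compound 4. Compound 4 is accordingly estimated at 110000 nM in this assay, with an expected range from 50000 nM to 250000 nM, and a fair chance that this assay again reports only a limit rather than a number.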

Compound 4, half-maximal cytotoxic concentration: > 100000 nM
Compound 4: a limit, no number (the forecaster's own chance of this, stated with the estimate: 55%); the middle value does not contradict the limit.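

Compound 3 and compound 4 both return a limit and not a number in this assay, so no step can be read between them: the limit of > 100000 nM in this assay, at which 2 of the 4 values shown sit.

The compounds shown leave open whether the double bond drawn Z or E makes any difference in this assay to how much compound is tolerated.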